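Aryl amide replaces cyclobutyl amide on a shared naphthalene-free core

This account rests on a few compounds, and the source may have more. Where it says the series, first, only, none or still open, it means among the compounds named here.

Measured compounds:
- compound 1, `CCCC(=O)Nc1c(C(O)(C(F)(F)F)C(F)(F)F)ccc2ccccc12`, gives 708 nM in a functional assay (Sus scrofa) with sulfonylurea receptors; K-ATP channels (Homo sapiens) as the target; a lower number here means that less compound is needed, a higher number that more compound is needed for the effect
- compound 2, `C/C=C/C(=O)Nc1c(C(O)(C(F)(F)F)C(F)(F)F)ccc2ccccc12`, gives 49 nM in this assay
- compound 3, `O=C(Nc1c(C(O)(C(F)(F)F)C(F)(F)F)ccc2ccccc12)C1CCC1`, gives 81.3 nM in this assay

Compound 3 stands second highest of the three numbers: its value differs from compound 2 by a 1.7-fold higher number from compound 2 to compound 3 (0.22 log units; within the scatter), a gap within the scatter, while its distance from compound 1 is an 8.7-fold lower number from compound 1 to compound 3 (0.94 log units; beyond the scatter). Compound 4, `O=C(Nc1c(C(O)(C(F)(F)F)C(F)(F)F)ccc2ccccc12)c1cccc(Cl)c1`, is not yet measured. It differs from compound 3 by 3-chlorophenyl in place of cyclobutyl on a carbonyl carbon. Among the compounds with values here, no measured step swaps a ring for an aromatic ring, so the known steps bear only loosely on it; they show that small changes on the carbonyl carbon moved the number by a 14-fold lower number from compound 1 to compound 2 (1.16 log units; beyond the scatter) and by an 8.7-fold lower number from compound 1 to compound 3 (0.94 log units; beyond the scatter). The expected step is therefore a 1.8-fold higher number from compound 3 to compound 4 (0.27 log units; within the scatter), with wide uncertainty in either direction. Compound 4 is estimated at 150 nM, between 30 nM and 700 nM.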

Compound 4, half-maximal effective concentration: 851 nM
Beside the measured number, compound 4's estimate is 5.7-fold (0.75 log units) below it, and the stated range ends below it.
By their numbers in this assay, from the lowest: compounds 2 and 3 (each within the scatter of the next); then compounds 1 and 4 (each within the scatter of the next).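

In this assay the only aromatic ring shown on this carbonyl carbon gives a 10-fold higher number from compound 3 to compound 4 (1.02 log units; beyond the scatter) and a 17-fold higher number from compound 2 to compound 4 (1.24 log units; beyond the scatter) and so shows that a larger ring here is not simply tolerated. Against the plain chain, it gives a 1.2-fold higher number from compound 1 to compound 4 (0.08 log units; within the scatter) and brings no gain over propyl. Nothing shown explains this loss.

Going by these compounds, whether the loss comes from the aromatic ring, its size or the chlorine stays open. Unsubstituted phenyl and cyclohexyl on the same carbonyl carbon would help to separate these possibilities.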